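Naphthyl for methoxyphenyl on a bromo-oxindole pyrazoline

The source may report more compounds than this note shows. Statements on the series, on what has been measured and on what is new or still open speak of the compounds shown alone.

Compound 2 `COc1ccc(C2=NN(C3=NC(=O)/C(=C4\C(=O)Nc5ccc(Br)cc54)S3)C(c3ccc(OC)cc3)C2)cc1` gives 380 nM in a functional assay on cells (Cancer cell lines, Homo sapiens) for cytotoxicity, read by sulforhodamine B assay, with a stated time of 48 h (on this read-out lower numbers stand for stronger inhibition of growth and higher numbers for weaker inhibition of growth), and holds the lowest number of the three measured compounds. Compound 3 `COc1ccc(C2=NN(C3=NC(=O)/C(=C4\C(=O)Nc5ccc(Cl)cc54)S3)C(c3ccc(OC)cc3)C2)cc1` gives 390 nM in this assay, and a 1.0-fold higher number from compound 2 to compound 3 (0.01 log units; within the scatter). Compound 1 `COc1ccc(C2=NN(C3=NC(=O)/C(=C4\C(=O)Nc5ccccc54)S3)C(c3ccc(OC)cc3)C2)cc1` gives 100000 nM; the steps of a 260-fold lower number from compound 1 to compound 2 (2.42 log units; beyond the scatter) and a 260-fold lower number from compound 1 to compound 3 (2.41 log units; beyond the scatter) both concern the aromatic carbon of the shared core. Compound 4 `COc1ccc(C2CC(c3ccc4ccccc4c3)=NN2C2=NC(=O)/C(=C3\C(=O)Nc4ccc(Br)cc43)S2)cc1` differs from compound 2 elsewhere: naphthalen-2-yl in place of 4-methoxyphenyl on a carbon with a double bond to nitrogen. Going by the values given here, no measured step touches this position, so nothing in the data speaks for a shift beyond the scatter in either direction in this assay. Compound 4 is therefore expected to give about 450 nM, within 100 nM to 2500 nM, an expected step of a 1.2-fold higher number from compound 2 to compound 4 (0.07 log units; within the scatter).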

Compound 4, concentration for total growth inhibition: 330 nM
Compound 4: middle estimate off by 1.4-fold (0.13 log units), on the high side; measured number inside the range.
By their numbers in this assay, from the lowest: compounds 4, 2 and 3 (each within the scatter of the next); then compound 1.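

In this assay, the position on the carbon with a double bond to nitrogen accepts naphthalen-2-yl in place of 4-methoxyphenyl, with a 1.2-fold lower number from compound 2 to compound 4 (0.06 log units; within the scatter), so a second aromatic ring and the loss of the methoxy oxygen leave the bromo compound's number unchanged within the scatter. The earlier steps shown here changed only the aromatic carbon of the shared core and said nothing about this position. Nothing available offers a reason for this result. Going by these compounds, it remains open whether an amine or a carboxylic acid on the aryl ring at this position would keep the number, and whether naphthalen-2-yl would do the same with chloro or hydrogen in place of bromo.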